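The compounds below may be only part of what the source reports. "The series", "measured", "known", "first", "only" and "open" are said of these compounds alone.

Compound 1 `COc1cc(OC)c(-c2coc3cc(OCc4ccccc4)ccc3c2=O)cc1OC`: 9750 nM
Compound 2 `COc1cc(OC)c(-c2coc3cc(OCc4cccc(F)c4)ccc3c2=O)cc1OC`: 5300 nM

In a functional assay on HUVEC cells (Homo sapiens) for antiproliferative activity, read by MTT assay, with a stated time of 24 h (a lower number here means a stronger inhibitor, a higher number a weaker inhibitor), compound 2 gives 5300 nM and compound 1 gives 9750 nM, two values within the scatter of each other. Compound 3 `COc1cc(OC)c(-c2coc3cc(OCc4ccccc4Cl)ccc3c2=O)cc1OC` differs from compound 2 as follows: 2-chlorophenyl in place of 3-fluorophenyl on a saturated chain carbon bound to an oxygen on an aromatic ring. Going by the values given here, the only measured step that bears on this change is a 1.8-fold lower number from compound 1 to compound 2 (0.26 log units; within the scatter), where fluoro replaced hydrogen on the same phenyl group. Among the compounds with values here, no compound with chlorine has been measured yet. The expected change, a 1.2-fold higher number from compound 2 to compound 3 (0.09 log units; within the scatter), is therefore none beyond the scatter. For compound 3 the estimated value is 6500 nM, with an expected range from 2500 nM to 16000 nM.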

Compound 3, half-maximal inhibitory concentration: > 10000 nM
Compound 3 ended at the assay's limit; the forecaster's own chance of this, stated with the estimate: 5%; middle value at least 1.5-fold (0.18 log units) away from the limit.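

In this assay compound 3 gives > 10000 nM, which is a limit and not a number: the limit of > 10000 nM in this assay, at which 1 of the 3 values shown sits.

Going by these compounds, the steps of an at least 1.8-fold higher number from compound 2 to compound 3 (0.27 log units; that floor lies within the scatter) and an at least 1.0-fold higher number from compound 1 to compound 3 (0.01 log units; that floor lies within the scatter) are therefore floors, so their true sizes remain unknown. Unlike the fluoro change, this first chlorine-bearing change on the phenyl group gives a value that reaches the limit.

Since 2-chlorophenyl differs from 3-fluorophenyl in both the halogen and its place on the ring, the two effects cannot be separated; a 3-chlorophenyl group would help to tell them apart. On these data alone, how an amine on this phenyl group would read also remains open.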